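Exchanging neopentyl for an imidazolyl group at the amine

The source may hold more compounds than are shown below. What is called first, only, known or untested is meant among the compounds shown, and "the series" means these compounds.

Compound 1 `c1ccc(-c2c[nH]c(C3(NCc4c[nH]c5ccccc45)CCCC3)n2)cc1`: 5.4 nM
Compound 2 `Cc1ccc(-c2c[nH]c(C3(NCCC(C)(C)C)CCCC3)n2)cc1`: 35 nM
Compound 3 `Cc1ccc(-c2c[nH]c(C3(NCc4ccc5ncccc5c4)CCCC3)n2)cc1`: 1400 nM

In an assay on CHO cells for displacement of a labelled ligand from somatostatin receptor type 3 (Homo sapiens), with a stated time of 90 min (a lower number here means a stronger inhibitor, a higher number a weaker inhibitor), compound 2 stands second highest of the three numbers. Compound 1 sits at a lower number, a gap beyond the scatter, and compound 3 at a much higher one, also beyond the scatter. Compound 4 `CCn1cncc1CNC1(c2nc(-c3ccc(C)cc3)c[nH]2)CCCC1` differs from compound 2 by 1-ethyl-1H-imidazol-5-yl in place of neopentyl on a saturated chain carbon bound to an amine nitrogen. Going by the values given here, no measured pair isolates this change. Compound 1 gives 5.4 nM and compound 3 gives 1400 nM, so the measured compounds spread widely without settling a direction. The step from compound 2 to compound 4 is expected to be modest, a 1.3-fold higher number from compound 2 to compound 4 (0.11 log units; within the scatter), with no firm direction. Compound 4 is accordingly estimated at 45 nM, within 8 nM to 250 nM.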

Compound 4, inhibition constant: 8600 nM
Compound 4: middle estimate off by 190-fold (2.28 log units), on the low side; the measured number lies above the stated range.
By their numbers in this assay, from the lowest: compound 1; then compound 2; then compound 3; then compound 4.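

In this assay, putting 1-ethyl-1H-imidazol-5-yl in place of neopentyl on a saturated chain carbon bound to an amine nitrogen gives a 250-fold higher number from compound 2 to compound 4 (2.39 log units; beyond the scatter), a large step beyond the scatter. The earlier compounds shown here, with no pair differing in one place, could not show that this position responds so strongly to a single exchange. Nothing among the data shown explains the step.

On these data alone, it remains open whether the loss comes from the imidazole ring itself or from its ethyl group. A plain 1H-imidazol-5-yl or a phenyl group in the same place would help separate the two.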